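Sulfonamide oxadiazoles: fluoro to chloro on the aryl

The source may hold more compounds than are shown below. What is called first, only, known or untested is meant among the compounds shown, and "the series" means these compounds.

Two compounds of the series have numbers in an assay on cells for inhibition of Amine oxidase [flavin-containing] A (Homo sapiens), read by fluorescence and spectrophotometry, using microsomes, with a stated time of 20 min (on this read-out higher numbers stand for weaker inhibition and lower numbers for stronger inhibition), so far. Compound 1 `NS(=O)(=O)c1cccc(-c2nnc(-c3ccc(F)cc3)o2)c1` gives 34400 nM in this assay. Compound 2 `NS(=O)(=O)c1ccc(-c2nnc(-c3ccc(Cl)c(Cl)c3)o2)cc1` gives 46200 nM in this assay. Compound 1 has the lower of the two numbers, but the gap to compound 2 lies within the scatter, so the two cannot be ordered.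

Compound 3 `NS(=O)(=O)c1cccc(-c2nnc(-c3ccc(Cl)cc3)o2)c1` is not yet measured. It differs from compound 1 by chloro in place of fluoro on an aromatic carbon, the place being an aromatic carbon of a six-membered aromatic ring of carbon only. Among the measured compounds shown here, no measured pair shows this change, so there is nothing to read a step from. The expectation is a step from compound 1 to compound 3 of a 1.4-fold lower number from compound 1 to compound 3 (0.14 log units; within the scatter), not clearly beyond the scatter, with a slight lean toward a lower number. For compound 3 the estimated value in this assay is 25000 nM, expected to fall between 10000 nM and 70000 nM.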

Compound 3, half-maximal inhibitory concentration: > 100000 nM
Compound 3 gave a limit, no number (the forecaster's own chance of this, stated with the estimate: 10%); middle value at least 4.0-fold (0.60 log units) away from the limit.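

In this assay compound 3 gives > 100000 nM, which is a limit of the assay and not a number. Chloro in place of fluoro, on an aromatic carbon para to a large group, supplies the first single-place comparison in the series and gives an at least 2.9-fold higher number from compound 1 to compound 3 (0.46 log units; beyond the scatter), so on this read-out the position does not take this change without a loss. The full size of the step cannot be given because only one side of it is a number: the limit of > 100000 nM in this assay, at which 1 of the 3 values shown sits.

On these data alone, whether an amine or a methoxy group in place of the fluoro would keep the value of compound 1 stays open. Also open, as far as these compounds go, is whether the step from fluoro to chloro carries over to the core of compound 2.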